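This account rests on a few compounds, and the source may have more. Where it says the series, first, only, none or still open, it means among the compounds named here.

Compound 1 `CCC1=C(O)c2c(oc(-c3ccc(CC)cc3)cc2=O)C(CC)(CC)C1=O`: 21.9 uM
Compound 2 `CCC1=C(O)c2c(oc(-c3ccc(F)cc3)cc2=O)C(CC)(CC)C1=O`: 33 uM

In a functional assay on KB cells (Homo sapiens) for antiproliferative activity, read by sulforhodamine B assay, with a stated time of 3 days (a higher number here means that more compound is needed for the effect, a lower number that less compound is needed), compound 2 gives 33 uM, level with compound 1 at 21.9 uM once the usual scatter is allowed for. Compound 3 `CCC1=C(O)c2c(oc(-c3ccc(CBr)cc3)cc2=O)C(CC)(CC)C1=O` has not yet been measured. It carries bromomethyl in place of fluoro on an aromatic carbon. For the measured compounds named here, the only measured swap on this carbon gave a 1.5-fold higher number from compound 1 to compound 2 (0.18 log units; within the scatter), so no step beyond the scatter is expected in this assay, in either direction. The expected change is a 1.3-fold lower number from compound 2 to compound 3 (0.12 log units; within the scatter). The estimate for compound 3 is 25 uM, with an expected range of 9 uM to 55 uM.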

Compound 3, concentration for half-maximal effect: > 46.5 uM
Compound 3: no number, only a limit (the forecaster's own chance of this, stated with the estimate: 10%); at least 1.8-fold (0.26 log units) between middle value and limit.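

In this assay compound 3 gives > 46.5 uM, which is a limit of the assay and not a number. This aromatic carbon is therefore not indifferent to what it carries: an at least 2.1-fold higher number from compound 1 to compound 3 (0.32 log units; beyond the scatter), whereas an at least 1.4-fold higher number from compound 2 to compound 3 (0.14 log units; that floor lies within the scatter), and the earlier swap stayed within the scatter. The full size of both steps stays unknown because only a limit is available: the limit of > 46.5 uM in this assay, at which 1 of the 3 values shown sits.

The compounds shown leave open whether the bromine or the added carbon matters more. From the compounds shown here alone, how hydroxymethyl, aminomethyl or a carboxylic acid would read on this carbon also remains open.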